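Ring size at the chain end: pyrrolidine to piperidine

The source may report more compounds than this note shows. Statements on the series, on what has been measured and on what is new or still open speak of the compounds shown alone.

Compound 1, `COc1cc2c(Oc3ccc(NC(=O)c4nc(-c5ccc(F)cc5)no4)cc3)ccnc2cc1OCCCN1CCC(C)CC1`, gives 870 nM in a functional assay on A549 cells (Homo sapiens) for antiproliferative activity, read by MTT assay, with a stated time of 72 h; a lower number here means a stronger inhibitor, a higher number a weaker inhibitor.
Compound 2, `COc1cc2c(Oc3ccc(NC(=O)C4(c5nnc(-c6ccc(F)cc6)o5)CC4)cc3F)ccnc2cc1OCCCN1CCCC1`, gives 150 nM in this assay.
Compound 3, `COc1cc2c(Oc3ccc(NC(=O)c4ncc(-c5ccc(F)cc5)o4)cc3)ccnc2cc1OCCCN1CCC(C)CC1`, gives 240 nM in this assay.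

Compound 2 gives the lowest of the three numbers. Compound 3 sits within the scatter of it, so the two cannot be ordered; compound 1 lies beyond the scatter above both. Among the compounds with values here, the one single-point step in the set is a 3.6-fold lower number from compound 1 to compound 3 (0.56 log units; beyond the scatter), which concerns the heteroaryl ring on the carbonyl carbon and says nothing about the amine at the end of the chain.

Compound 4, `COc1cc2c(Oc3ccc(NC(=O)C4(c5nnc(-c6ccc(F)cc6)o5)CC4)cc3F)ccnc2cc1OCCCN1CCCCC1`, differs from compound 2 in just that chain end: piperidin-1-yl in place of pyrrolidin-1-yl on a saturated chain carbon, three bonds along the chain from an oxygen on an aromatic ring. Within the data shown here, no measured pair in this set isolates this change, so there is no step on which to rest an expectation of movement. Compound 4 is therefore expected to land close to compound 2 in this assay, with no change at the digits printed from compound 2 to compound 4 (within the scatter) as the expected step, which should stay within the scatter. The estimate for compound 4 in this assay is 150 nM, with a range from 75 nM to 300 nM.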

Compound 4, half-maximal inhibitory concentration: 53 nM
For compound 4 the middle estimate is 2.8-fold (0.45 log units) above the measured one, and the stated range ends above it.
By their numbers in this assay, from the lowest: compound 4; then compounds 2 and 3 (each within the scatter of the next); then compound 1.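

In this assay the end of the propyl chain proves to be a position that responds: piperidin-1-yl in place of pyrrolidin-1-yl gives a 2.8-fold lower number from compound 2 to compound 4 (0.45 log units; beyond the scatter), a step beyond the scatter. Within the data shown here, the earlier compounds could not show this, since their only step concerned the heteroaryl ring on the carbonyl carbon and left the chain end untouched. The two groups differ by one ring carbon and in ring size, with the same count of hydrogen-bond donors and acceptors and no net charge on either, and nothing measured here accounts for the step.

Going by these compounds, this is a single pair in a single assay, so it remains open whether a larger ring end would generally go with a lower number, and whether the same swap would act alike on the core of compound 1 or compound 3, both of which carry a methyl-substituted piperidine and differ from compound 4 in more than one place. On these data alone, it also remains open how a morpholin-4-yl or 4-methylpiperazin-1-yl group, or an open-chain dimethylamino group, would compare with piperidin-1-yl at this chain end.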